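Replacing a phenylcarbamoyl with a methyl-lactam on the core

This account rests on a few compounds, and the source may have more. Where it says the series, first, only, none or still open, it means among the compounds named here.

Measured compounds:
compound 1 `O=C(Nc1ccccc1)c1cnc(NCc2c(F)ccc3c2CCO3)n2cnnc12` with 4.1
compound 2 `O=C1CCCN1c1cnc(NCc2c(F)ccc3c2CCO3)c2cn[nH]c(=O)c12` with 1.8
compound 3 `CC(=O)N1CCC(c2cnc(NCc3c(F)ccc4c3CCO4)c3cn[nH]c(=O)c23)CC1` with 2.9

In a physicochemical assay for lipophilicity, using the shake flask method, in phosphate buffer, measured as octanol-water partition, with a stated time of 30 min, at pH 7.4 (on this read-out lower numbers stand for lower lipophilicity and higher numbers for higher lipophilicity), compound 1 stands highest of the three, with compound 3 nearest and compound 2 furthest away. Compound 4 `C[C@H]1CC(=O)N(c2cnc(NCc3c(F)ccc4c3CCO4)n3cnnc23)C1` differs from compound 1 in one place: 4-methyl-2-oxopyrrolidin-1-yl in place of phenylcarbamoyl on an aromatic carbon. For the measured compounds named here, no measured step swaps these two groups directly; the only step of the set, a number 1.10 log units higher from compound 2 to compound 3 (beyond the scatter), exchanges one ring group for another on a different core and shows that such exchanges can move this assay well beyond the scatter. A group of 9 heavy atoms with an aromatic ring leaves and a smaller non-aromatic one enters, so compound 4 is expected to fall clearly, by a number 1.60 log units lower from compound 1 to compound 4 (beyond the scatter). The estimate for compound 4 is 2.5, within 1.8 to 3.2.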

Compound 4, distribution coefficient: 1.8
Compound 4: the middle estimate sits 0.70 log units above what was measured; the range from low to high includes it.
By their numbers in this assay, from the lowest: compounds 2 and 4 (each within the scatter of the next); then compound 3; then compound 1.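

At this position, on an aromatic carbon of the shared core, 4-methyl-2-oxopyrrolidin-1-yl in place of phenylcarbamoyl gives a number 2.30 log units lower from compound 1 to compound 4 (beyond the scatter) in this assay. Unlike the earlier step, which was read on a different core, this one reads the exchange at this position directly and shows that it alone moves the number beyond the scatter. Nothing available explains the size of this step. Going by these compounds, it remains open whether the phenyl ring, the amide hydrogen or the lactam ring accounts for the step. Also open, on these data alone, is where a simple amine or an open-chain acetamide at this position would fall.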